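Swapping Sulfamoyl for Fluoro on a Weak Inhibitor

A few compounds are considered here, and "the series" means these few. Any claim that something is new, unique, unknown or untested is made for them only; others in the source may bear on it.

In a functional assay on Ehrlich cells (Mus musculus) for inhibition (a higher number here means a weaker inhibitor, a lower number a stronger inhibitor), three compounds sharing one core have been measured. Compound 1 `O=C(O)c1ccc2c(O)c(C(=O)O)cnc2c1` gives 5750000 nM, compound 2 `COc1ccc2c(O)c(C(=O)O)cnc2c1` gives 525000 nM, and compound 3 `NS(=O)(=O)c1ccc2c(O)c(C(=O)O)cnc2c1` gives 3390000 nM. Compound 2 is the strongest inhibitor of the three. Compound 3 stands close to compound 1, with a 1.7-fold lower number from compound 1 to compound 3 (0.23 log units; within the scatter), and well away from compound 2, with a 6.5-fold higher number from compound 2 to compound 3 (0.81 log units; beyond the scatter).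

The next compound, compound 4 `O=C(O)c1cnc2cc(F)ccc2c1O`, has not been measured. It carries fluoro in place of sulfamoyl on an aromatic carbon. Among the compounds with values here, no measured compound carries fluoro, so the evidence is indirect. Two measured steps show that changing this group can matter: methoxy in place of carboxy gave the large 11-fold lower number from compound 1 to compound 2 (1.04 log units; beyond the scatter), and sulfamoyl in place of methoxy gave the modest step already noted. Sulfamoyl in place of carboxy stayed within the scatter. So far, only methoxy has moved the number clearly away from the other two compounds, and whether fluoro behaves likewise is unknown. A modest drop is therefore expected, stopping short of the value of compound 2, and the expected step is a 3.4-fold lower number from compound 3 to compound 4 (0.53 log units; beyond the scatter). For compound 4 the estimated value in this assay is 1000000 nM, with an expected range from 300000 nM to 3500000 nM.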

Compound 4, half-maximal inhibitory concentration: 501000 nM
Compound 4: the middle estimate sits 2.0-fold (0.30 log units) above what was measured; low and high end bracket the measured number.
By their numbers in this assay, from the lowest: compounds 4 and 2 (each within the scatter of the next); then compounds 3 and 1 (each within the scatter of the next).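

Swapping sulfamoyl for fluoro on this aromatic carbon in this assay gives a 6.8-fold lower number from compound 3 to compound 4 (0.83 log units; beyond the scatter) and swapping carboxy for fluoro gives an 11-fold lower number from compound 1 to compound 4 (1.06 log units; beyond the scatter), so a second group now stands clearly apart from sulfamoyl and carboxy. Fluoro and methoxy cannot be told apart in this assay, with a 1.0-fold lower number from compound 2 to compound 4 (0.02 log units; within the scatter), which means that methoxy is no longer the only group here tied to a lower number. The four compounds thus fall into two pairs, with fluoro and methoxy giving the lower numbers and sulfamoyl and carboxy the higher ones, and none of the four goes against this split, although it rests on only these four groups.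

Nothing available here explains why the groups divide in this way. Chloro, methyl or an amine on the same aromatic carbon would show whether other groups join the fluoro and methoxy pair, join the sulfamoyl and carboxy pair, or reach a number outside both.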